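A few compounds are considered here, and "the series" means these few. Any claim that something is new, unique, unknown or untested is made for them only; others in the source may bear on it.

Measured in a functional assay on the whole organism (strain Sprague-Dawley) for inhibition, with Rattus norvegicus as the target; on this read-out higher numbers stand for an effect only at larger amounts of compound and lower numbers for an effect already at smaller amounts:
compound 1 `COc1ccc2c(=O)c(-c3nn[nH]n3)c[nH]c2c1` gives 10 mg/kg
compound 2 `O=c1c(-c2nn[nH]n2)c[nH]c2ccccc12` gives 1.25 mg/kg
compound 3 `Cc1ccc2[nH]cc(-c3nn[nH]n3)c(=O)c2c1` gives 1.25 mg/kg

Compound 2 stands level with compound 3 at the digits given, and together they hold the lowest of the three numbers; the only separation in the set is an 8.0-fold lower number from compound 1 to compound 2 (0.90 log units; beyond the scatter), which places compound 1 apart. The step of no change at the digits printed from compound 2 to compound 3 (within the scatter) shows that a methyl entering on an aromatic carbon of the shared core leaves the number where it was.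

Compound 4 `CCc1ccc2c(=O)c(-c3nn[nH]n3)c[nH]c2c1` differs from compound 2 by ethyl in place of hydrogen on an aromatic carbon. Within the data shown here, two measured steps bear on this: no change at the digits printed from compound 2 to compound 3 (within the scatter) is the closest precedent, a small alkyl entering at the same kind of position, and it was flat; an 8.0-fold lower number from compound 1 to compound 2 (0.90 log units; beyond the scatter) shows that a methoxy at that position is tolerated much worse, but methoxy is not an alkyl. On this basis no step beyond the scatter is expected in this assay, with at most a slight drift toward higher numbers. Compound 4 is estimated at 2 mg/kg, within 0.8 mg/kg to 5 mg/kg. The expected step is a 1.6-fold higher number from compound 2 to compound 4 (0.20 log units; within the scatter).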

Compound 4, minimum effective dose: < 5 mg/kg
Compound 4 ended at the assay's limit (the forecaster's own chance of this, stated with the estimate: 5%); the middle value does not contradict the limit.
By their numbers in this assay, from the lowest: compounds 2 and 3 (each within the scatter of the next); then compound 1.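

In this assay compound 4 gives < 5 mg/kg, which is a limit of the assay and not a number, so the step from compound 2 to compound 4 cannot be read. Among these compounds, the carbon bearing methoxy in compound 1 now carries ethyl, giving the first alkyl comparison at that place: an at least 2.0-fold lower number from compound 1 to compound 4 (0.30 log units; that floor lies within the scatter). That floor alone does not set compound 4 apart from compound 1, so a real gain from exchanging methoxy for ethyl remains unproven.

On these data alone, whether ethyl matches hydrogen at this carbon stays open until compound 4 has a readable number. Also open, as far as these compounds go, is how a longer chain such as propyl, an amine or a carboxylic acid at the same carbon would compare with ethyl and methoxy.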